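Compound 1 to compound 4: an isomeric ring change

The compounds below may be only part of what the source reports. "The series", "measured", "known", "first", "only" and "open" are said of these compounds alone.

Values in an ADME assay on Vero cells (Chlorocebus sabaeus) for cytotoxicity, read by MTT assay, with a stated time of 72 h (a higher number here means that more compound is tolerated, a lower number that less compound is tolerated), for the measured compounds:
- compound 1 `CC1=C(/C=C/C2=NN(c3ccccc3)C(c3ccc(-n4cncn4)cc3)C2)C(C)(C)CCC1` gives 112000 nM
- compound 2 `CC1=C(/C=C/C2=NN(c3ccc(F)cc3)C(c3ccc(-n4cncn4)cc3)C2)C(C)(C)CCC1` gives 58600 nM
- compound 3 `CC1=CCCC(C)(C)C1/C=C/C(=O)/C=C/c1ccc(-n2cncn2)cc1` gives 38500 nM

Compound 1 sits within the scatter of compound 2, as the step of a 1.9-fold lower number from compound 1 to compound 2 (0.28 log units; within the scatter) shows, and its number is higher than that of compound 3 by a gap beyond the scatter.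

Compound 4 `CC1=CCCC(C)(C)C1/C=C/C1=NN(c2ccccc2)C(c2ccc(-n3cncn3)cc2)C1` is still to be measured. It has the same atoms as compound 1, joined differently. The difference 2,6,6-trimethylcyclohex-2-en-1-yl in place of 2,6,6-trimethylcyclohex-1-en-1-yl on a double-bonded chain carbon bound to a double-bonded chain carbon amounts to 2,6,6-trimethylcyclohex-2-en-1-yl in place of 2,6,6-trimethylcyclohex-1-en-1-yl on a double-bonded chain carbon bound to a double-bonded chain carbon.

For the measured compounds named here, no measured pair isolates this change. Going by the values given here, the only step available is a 1.9-fold lower number from compound 1 to compound 2 (0.28 log units; within the scatter) for fluoro in place of hydrogen on an aromatic carbon, a change elsewhere in the molecule. Among the compounds with values here, compound 3 (38500 nM) also carries the entering group, but the rest of its structure differs, so its value gives no step for this change. In this assay, going by these compounds, no shift beyond the scatter is therefore expected, and the direction stays open. The estimated step is a 1.2-fold lower number from compound 1 to compound 4 (0.07 log units; within the scatter) and it remains an expectation only. Compound 4 is estimated at 95000 nM with an expected range from 48000 nM to 190000 nM until the measurement is available.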

Compound 4, half-maximal cytotoxic concentration: 296000 nM
Estimate against measurement, compound 4: 3.1-fold (0.49 log units) below, and the stated range ends below it.
By their numbers in this assay, from the lowest: compounds 3, 2 and 1 (each within the scatter of the next, the first and the last beyond it); then compound 4.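

In this assay, 2,6,6-trimethylcyclohex-2-en-1-yl in place of 2,6,6-trimethylcyclohex-1-en-1-yl on a double-bonded chain carbon bound to a double-bonded chain carbon gives a 2.6-fold higher number from compound 1 to compound 4 (0.42 log units; beyond the scatter), so the number at this position responds beyond the scatter to a change that keeps the atoms and the counts of the group the same. Until now the only single-place step in the series was a 1.9-fold lower number from compound 1 to compound 2 (0.28 log units; within the scatter), which lay within the scatter and concerned another part of the molecule, so this is the first single-place change shown to move the number beyond the scatter, and it moves towards more compound being tolerated. No measurement available here bears on why the two isomeric groups differ.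

Going by these compounds, the shift rests on one pair, so it stays open whether the same exchange would give a comparable step on the fluoro-bearing compound 2. Also open, on these data alone, is how the number would respond at this place to a cyclohexyl group with no ring double bond, or to a tert-butyl group.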